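The source may hold more compounds than are shown below. What is called first, only, known or untested is meant among the compounds shown, and "the series" means these compounds.

Compound 1 `O=C(/C(=C\c1c[nH]c2ccccc12)SCc1ccc(F)cc1)c1ccc(Cl)cc1`: 1000 nM
Compound 2 `O=C(/C(=C\c1ccc(O)cc1)SCc1ccc(F)cc1)c1ccc(Br)cc1`: 10000 nM
Compound 3 `Cc1ccsc1/C=C(/SCc1ccc(F)cc1)C(=O)c1ccc(Cl)cc1`: 50000 nM

In a functional assay on DU-145 cells (Homo sapiens) for inhibition, read by trypan blue exclusion, with a stated time of 96 h (on this read-out lower numbers stand for stronger inhibition of growth and higher numbers for weaker inhibition of growth), compound 3 gives 50000 nM, the highest number of the three and so the weakest inhibition of growth in this small set. Compound 4 `O=C(/C(=C\c1ccc(O)cc1)SCc1ccc(F)cc1)c1ccc(Cl)cc1` has 4-hydroxyphenyl in place of 3-methylthiophen-2-yl on a double-bonded chain carbon bound to a double-bonded chain carbon. Among the measured compounds shown here, one measured step touches this place: a 50-fold higher number from compound 1 to compound 3 (1.70 log units; beyond the scatter), a large rise on exchanging 1H-indol-3-yl for 3-methylthiophen-2-yl. It shows that the number can move far here, but it does not involve 4-hydroxyphenyl. A closer guide is compound 2, which carries 4-hydroxyphenyl but holds bromine where compound 4 holds chlorine. No measurement here isolates that exchange of halogens. With compound 2 at 10000 nM as the guide, the expected step is a 5.0-fold lower number from compound 3 to compound 4 (0.70 log units; beyond the scatter), a fall beyond the scatter. For compound 4 the estimated value is 10000 nM, within an expected range of 3500 nM to 28000 nM.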

Compound 4, concentration for 50% growth inhibition: 25000 nM
The estimate for compound 4 lay 2.5-fold (0.40 log units) below the measured number; low and high end bracket the measured number.
By their numbers in this assay, from the lowest: compound 1; then compound 2; then compounds 4 and 3 (each within the scatter of the next).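

In this assay the exchange of 3-methylthiophen-2-yl for 4-hydroxyphenyl on a double-bonded chain carbon bound to a double-bonded chain carbon gives a step within the scatter (a 2.0-fold lower number from compound 3 to compound 4 (0.30 log units; within the scatter)), so these two groups cannot be told apart at this place. 1H-indol-3-yl does stand apart from 4-hydroxyphenyl here, by a large step (a 25-fold higher number from compound 1 to compound 4 (1.40 log units; beyond the scatter)). Among the compounds shown here, the result also gives the first reading of the halogen, since chloro in place of bromo on an aromatic carbon gives a modest step beyond the scatter (a 2.5-fold higher number from compound 2 to compound 4 (0.40 log units; beyond the scatter)).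

No evidence here gives a reason for any of these steps. Still open, on these data alone, is whether the halogen step carries over to compounds with 1H-indol-3-yl, and how an amine or a carboxylic acid in place of the halogen would read.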